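Moving the indole attachment on a shared core

The source may hold more compounds than are shown below. What is called first, only, known or untested is meant among the compounds shown, and "the series" means these compounds.

Measured in a functional assay on HeLa cells (Homo sapiens) for inhibition, read by CCK-8 assay, with a stated time of 48 h; a higher number here means a weaker inhibitor, a lower number a stronger inhibitor:
Compound 1 `COc1cc(-c2ccnc3cc(-c4ccc(C)c(C)c4)nn23)cc(OC)c1OC`: 241 nM
Compound 2 `COc1cc(-c2ccnc3cc(-c4cccc(C#N)c4)nn23)cc(OC)c1OC`: > 10000 nM (a limit of the assay, not a number)
Compound 3 `COc1cc(-c2ccnc3cc(-c4ccc5cc[nH]c5c4)nn23)cc(OC)c1OC`: 125 nM

All three compounds share one core and differ only in a single aromatic group. Only compound 1 and compound 3 give true numbers, and these two cannot be ranked, since the step between them is a 1.9-fold lower number from compound 1 to compound 3 (0.29 log units; within the scatter). For compound 2 the reading is the limit of > 10000 nM in this assay, at which 1 of the 3 values shown sits. Compound 3 stands well clear of that limit, with an at least 80-fold lower number from compound 2 to compound 3 (1.90 log units; beyond the scatter).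

Compound 4 `COc1cc(-c2ccnc3cc(-c4cn(C)c5ccccc45)nn23)cc(OC)c1OC` changes the same group again: 1-methyl-1H-indol-3-yl in place of 1H-indol-6-yl on an aromatic carbon. In words, 1-methyl-1H-indol-3-yl replaces 1H-indol-6-yl on an aromatic carbon of the five-membered aromatic ring with 2 nitrogen.

Two measured steps show how differently a swap at this place can turn out. One was large, an at least 41-fold higher number from compound 1 to compound 2 (1.61 log units; beyond the scatter), and the other stayed small, a 1.9-fold lower number from compound 1 to compound 3 (0.29 log units; within the scatter). The new group is closer in kind to the 1H-indol-6-yl of compound 3 than to the 3-cyanophenyl of compound 2, so a small step is expected, leaning towards a higher number. The expected change is a 1.8-fold higher number from compound 3 to compound 4 (0.25 log units; within the scatter). Compound 4 is estimated at 220 nM, with an expected range from 40 nM to 2500 nM.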

Compound 4, half-maximal inhibitory concentration: 399 nM
The estimate for compound 4 lay 1.8-fold (0.26 log units) below the measured number, and the stated range covers the measured number.
By their numbers in this assay, from the lowest: compounds 3, 1 and 4 (each within the scatter of the next, the first and the last beyond it). At a limit, above all of these: compound 2.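

Going by these compounds alone, at this position the two indole groups are not interchangeable: going from 1H-indol-6-yl to 1-methyl-1H-indol-3-yl gives a real shift (a 3.2-fold higher number from compound 3 to compound 4 (0.50 log units; beyond the scatter)), one the earlier compounds could not show, since they held only one indole. The shift remains modest, and compound 4 cannot be told apart from the 3,4-dimethylphenyl compound (a 1.7-fold higher number from compound 1 to compound 4 (0.22 log units; within the scatter)), so a second indole group also fits at this carbon without a large penalty. Both indole compounds stay far from the reading of compound 2 (an at least 25-fold lower number from compound 2 to compound 4 (1.39 log units; beyond the scatter)), and that reading is a limit, not a number: the limit of > 10000 nM in this assay, at which 1 of the 4 values shown sits.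

Compound 4 differs from compound 3 in two ways at once, the attachment point of the indole and the methyl that replaces the hydrogen on the indole nitrogen, so the compounds shown cannot say which of the two accounts for the shift; 1H-indol-3-yl or 1-methyl-1H-indol-6-yl would separate them. Going by these compounds, whether a carboxylic acid or an amine on the phenyl ring would read like the nitrile of compound 2 or like the methyl groups of compound 1 also stays open.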